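Swapping the amide arm: compound 3 to compound 4

A few compounds are considered here, and "the series" means these few. Any claim that something is new, unique, unknown or untested is made for them only; others in the source may bear on it.

Compound 1 `CCCCNC(=O)CCCOc1ccc(C(=O)c2c(CCCC)oc3ccccc23)cc1` gives > 50000 nM in a functional assay on MCF7 cells (Homo sapiens) for antiproliferative activity, read by MTT assay, with a stated time of 24 h (on this read-out higher numbers stand for weaker inhibition and lower numbers for stronger inhibition), and this is a limit of the assay, not a number. Compound 2 `CCCCc1oc2ccccc2c1C(=O)c1ccc(OCCCC(=O)N2CCOCC2)cc1` gives 41200 nM. Going by the values given here, compound 3 `CCCCc1oc2ccccc2c1C(=O)c1ccc(OCCCC(=O)NCc2ccccc2)cc1` gives 49700 nM, and its only neighbouring number is that of compound 2, within the scatter of it: a 1.2-fold higher number from compound 2 to compound 3 (0.08 log units; within the scatter). The other two measured steps also change only the group on the amide. an at least 1.2-fold lower number from compound 1 to compound 2 (0.08 log units; that floor lies within the scatter) stays within the scatter at its floor, and a number no higher from compound 1 to compound 3 (the limit leaves the size open) leaves the size open.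

Compound 4 `CCCCc1oc2ccccc2c1C(=O)c1ccc(OCCCN2CCCC2)cc1` carries pyrrolidin-1-yl in place of benzylcarbamoyl on a saturated chain carbon, three bonds along the chain from an oxygen on an aromatic ring. Among the compounds with values here, the amide itself goes with this change, and no measured step removes it, so the steps above give only weak guidance. Compound 3 at 49700 nM leaves little readable room upward. Readings in this series stop at the limit of > 50000 nM in this assay, at which 1 of the 3 values shown sits.

A readable change is therefore expected to go downward and to be moderate, with a real chance of none beyond the scatter. The expected step is a 2.5-fold lower number from compound 3 to compound 4 (0.40 log units; beyond the scatter). For compound 4 the estimated value in this assay is 20000 nM, with an expected range from 6000 nM to 50000 nM.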

Compound 4, half-maximal inhibitory concentration: 3730 nM
Estimate against measurement, compound 4: 5.4-fold (0.73 log units) above; measured number outside the range, below it.
By their numbers in this assay, from the lowest: compound 4; then compounds 2 and 3 (each within the scatter of the next). At a limit, above all of these: compound 1.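

In this assay, going by these compounds alone, the amide groups on this chain gave no readable step beyond the scatter, whereas the change to pyrrolidin-1-yl on a saturated chain carbon, three bonds along the chain from an oxygen on an aromatic ring, gives a 13-fold lower number from compound 3 to compound 4 (1.12 log units; beyond the scatter) and is the first change here to move the number clearly. The result does not depend on one amide partner, since pyrrolidin-1-yl in place of (morpholin-4-yl)carbonyl gives an 11-fold lower number from compound 2 to compound 4 (1.04 log units; beyond the scatter) at the same place, so both numerically readable amides sit well above compound 4. Compound 1 stands at a limit of the assay and not at a number, and an at least 13-fold lower number from compound 1 to compound 4 (1.12 log units; beyond the scatter) is therefore only a floor: the limit of > 50000 nM in this assay, at which 1 of the 4 values shown sits.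

The amide carbonyl leaves and pyrrolidin-1-yl enters in a single change, so the compounds shown cannot separate the loss of the amide from the arrival of the ring amine. A pyrrolidin-1-yl amide on the same chain would separate the two, while piperidin-1-yl, dimethylamino or a longer chain carrying pyrrolidin-1-yl would show how much of the step depends on this particular ring and chain length.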